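Swapping the Five-Membered Ring: Thiophene to Furan

The source may hold more compounds than are shown below. What is called first, only, known or untested is meant among the compounds shown, and "the series" means these compounds.

Compound 1, `CC(C(=O)NCc1ccc(C(F)(F)F)nc1-c1ccc2c(c1)OCCO2)c1ccc(NS(C)(=O)=O)c(F)c1`: 5 nM
Compound 2, `CC(C(=O)NCc1ccc(C(F)(F)F)nc1-c1ccsc1)c1ccc(NS(C)(=O)=O)c(F)c1`: 2 nM

In an assay on CHO cells for antagonist activity at transient receptor potential cation channel subfamily V member 1 (Homo sapiens), read by FLIPR (a higher number here means a weaker inhibitor, a lower number a stronger inhibitor), compound 2 stands at the lowest number of the two; compound 1 sits higher, the step being a 2.5-fold lower number from compound 1 to compound 2 (0.40 log units; beyond the scatter). Compound 3, `CC(C(=O)NCc1ccc(C(F)(F)F)nc1-c1ccco1)c1ccc(NS(C)(=O)=O)c(F)c1`, has not been measured. It differs from compound 2 by furan-2-yl in place of thiophen-3-yl on an aromatic carbon. For the measured compounds named here, only one measured step bears on this position, a 2.5-fold lower number from compound 1 to compound 2 (0.40 log units; beyond the scatter), and it was modest. Since here one five-membered aromatic ring replaces another, the step of a 1.5-fold higher number from compound 2 to compound 3 (0.18 log units; within the scatter) is expected to be small, likely none beyond the scatter. Compound 3 is therefore estimated at 3 nM, within 1 nM to 10 nM.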

Compound 3, inhibition constant: 5.8 nM
Compound 3: middle estimate off by 1.9-fold (0.29 log units), on the low side, and the stated range covers the measured number.
By their numbers in this assay, from the lowest: compound 2; then compounds 1 and 3 (each within the scatter of the next).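

In this assay this position responds to a change between two five-membered rings of equal heavy-atom count: furan-2-yl in place of thiophen-3-yl gives a 2.9-fold higher number from compound 2 to compound 3 (0.46 log units; beyond the scatter) in a step that is modest. Against the 2,3-dihydro-1,4-benzodioxin-6-yl group, furan-2-yl shows a 1.2-fold higher number from compound 1 to compound 3 (0.06 log units; within the scatter) so thiophen-3-yl alone stands apart among these three compounds. No measurement here explains this difference.

This swap changes both the ring's hetero atom and its point of attachment, so a furan-3-yl or thiophen-2-yl group would be needed to separate the two. From the compounds shown here alone, how an amine would fare at this position remains open.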